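The compounds below may be only part of what the source reports. "The series", "measured", "known", "first", "only" and "open" are said of these compounds alone.

Measured compounds:
compound 1 `CCN(C(=O)c1ccc(Cl)c(Cl)c1C)[C@@H]1CCNC1`: > 40000 nM
compound 2 `O=C(c1ccc2ccccc2c1)N(C1CCCC1)[C@@H]1CCNC1`: 7400 nM

Going by the values given here, in an assay on HEK293 cells for inhibition of sodium-dependent dopamine transporter (Homo sapiens), read by scintillation counting, with a stated time of 5 min (on this read-out lower numbers stand for stronger inhibition and higher numbers for weaker inhibition), compound 2 gives 7400 nM, the only plain number in the set. For compound 1 this assay returns > 40000 nM, which is a limit of the assay and not a number (the limit of > 40000 nM in this assay, at which 1 of the 2 values shown sits). Among the compounds with values here, compound 2 is thus the one compound of the pair with a measured concentration, and there is no second number against which its position could be ranked.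

Compound 3 `O=C(c1ccc2ccccc2c1)N(C1CCC1)[C@@H]1CCNC1` is not yet measured in this assay. It differs from compound 2 in one place: cyclobutyl in place of cyclopentyl on an amide-type nitrogen, the amide-type nitrogen whose other neighbours are the carbonyl carbon and a saturated ring carbon. Within the data shown here, no measured pair in the set shows a step of this kind, so its size can only be estimated. The expectation is a step not beyond the usual scatter, if anything towards weaker inhibition. Compound 3 is therefore expected to give 9500 nM in this assay, within a range from 3500 nM to 30000 nM. The step this estimate implies, a 1.3-fold higher number from compound 2 to compound 3 (0.11 log units; within the scatter), is expected to stay within the scatter of repeated measurements.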

Compound 3, half-maximal inhibitory concentration: 5800 nM
Compound 3: the middle estimate sits 1.6-fold (0.21 log units) above what was measured, and the stated range covers the measured number.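

In this assay, going by these compounds alone, cyclobutyl in place of cyclopentyl on the amide-type nitrogen whose other neighbours are the carbonyl carbon and a saturated ring carbon gives a 1.3-fold lower number from compound 2 to compound 3 (0.11 log units; within the scatter), the first step that can be read at this position. With the rest of the structure held the same, the four-membered carbon ring and the five-membered carbon ring cannot be told apart on this read-out, so this one change in ring size on this nitrogen shows no measurable effect on the inhibition. No measurement shown gives a reason for this outcome.

Still open, going by these compounds, is how this position responds to groups of another kind, such as a cyclohexyl ring, a longer open chain such as n-butyl, or a ring holding an oxygen such as tetrahydropyranyl. Whether any group on this nitrogen can move the number beyond the scatter, in either direction, cannot be told from a single step between two closely related carbon rings.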